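A few compounds are considered here, and "the series" means these few. Any claim that something is new, unique, unknown or untested is made for them only; others in the source may bear on it.

Compounds measured so far in a functional assay on Jurkat cells (Homo sapiens) for inhibition; a lower number here means a stronger inhibitor, a higher number a weaker inhibitor:

Compound 1, `CCOC(=O)c1c(C)noc1OCC(=O)[C@H](CC(=O)O)NC(=O)[C@@H](NC(=O)COc1cccc2ccccc12)C(C)C`; for compound 1 the value is a limit of the assay, > 200000 nM.

Compound 2, `CC(C)[C@H](NC(=O)COc1cccc2ccccc12)C(=O)N[C@@H](CC(=O)O)C(=O)CSc1nnc(-c2ccccc2)o1`; compound 2 gives 150000 nM.

Among the compounds with values here, compound 2 stands as the only numbered value in this assay, the other entry being a limit. Within the data shown here, the one measured step, an at least 1.3-fold lower number from compound 1 to compound 2 (0.12 log units; that floor lies within the scatter), is itself bounded by the limit of > 200000 nM in this assay, at which 1 of the 2 values shown sits, and so gives no firm size.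

Compound 3, `CC(C)[C@H](NC(=O)COc1cccc2ccccc12)C(=O)N[C@@H](CC(=O)O)C(=O)CSc1nc[nH]n1`, differs from compound 2 by 1H-1,2,4-triazol-3-yl in place of 5-phenyl-1,3,4-oxadiazol-2-yl on a sulfur. Among the measured compounds shown here, no measured step addresses this change directly; the single step available, an at least 1.3-fold lower number from compound 1 to compound 2 (0.12 log units; that floor lies within the scatter), concerns the other heteroaryl at that chain carbon and is cut off by the limit of > 200000 nM in this assay, at which 1 of the 2 values shown sits. In this assay no step beyond the scatter is therefore expected for compound 3, and no change at the digits printed from compound 2 to compound 3 (within the scatter) is taken as the estimate. Compound 3 is expected at 150000 nM, within 50000 nM to 400000 nM.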

Compound 3, half-maximal inhibitory concentration: > 200000 nM
Compound 3 gave a limit, no number; the forecaster's own chance of this, stated with the estimate: 40%; middle value at least 1.3-fold (0.12 log units) from the limit.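

In this assay compound 3 gives a limit of the assay, > 200000 nM. The first change read on the sulfur itself, 1H-1,2,4-triazol-3-yl in place of 5-phenyl-1,3,4-oxadiazol-2-yl, gives an at least 1.3-fold higher number from compound 2 to compound 3 (0.12 log units; that floor lies within the scatter), so the smaller heteroaryl without the phenyl ring shows no gain over compound 2, while the step between compound 1 and compound 3 cannot be read. Most readings in this short series now rest on one limit: the limit of > 200000 nM in this assay, at which 2 of the 3 values shown sit.

On these data alone, the true size of the change on the sulfur stays open, as does whether any group there can give a number clearly beyond the scatter from compound 2. A pyridin-2-yl or a benzyl on the same sulfur would test whether an aromatic ring other than the phenyl-bearing oxadiazole gives a readable value in this assay.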